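The compounds below may be only part of what the source reports. "The series", "measured", "known", "first", "only" and "open" are said of these compounds alone.

Three compounds share one core and were tested in an in vitro functional assay on cells for agonist activity at Bombesin receptor subtype-3 (Homo sapiens), read by luminescence and calcium flux; on this read-out lower numbers stand for an effect already at smaller amounts and higher numbers for an effect only at larger amounts of compound. Compound 2 `Cc1ccccc1Cc1cnc(CCc2ccc(-c3ccccc3C(=O)O)cc2)[nH]1` gives 127 nM, the lowest of the three numbers. Among the compounds with values here, compound 1 `CCCCc1cnc(C(C)Cc2ccc(-c3ccccc3C(=O)O)cc2)[nH]1` gives 2760 nM, and compound 3 `CCCCc1cnc(C(Cc2ccc(-c3ccccc3C(=O)O)cc2)C(C)C)[nH]1` gives 4620 nM; the only measured step, a 1.7-fold higher number from compound 1 to compound 3 (0.22 log units; within the scatter), alters a saturated chain carbon and so bears little on the change considered here. Compound 4 `O=C(O)c1ccccc1-c1ccc(CCc2ncc(Cc3ccccc3Cl)[nH]2)cc1` differs from compound 2 by chloro in place of methyl on an aromatic carbon. Within the data shown here, no measured step touches that aromatic ring, so a shift beyond the scatter is not expected in either direction, and compound 4 is estimated in this assay at 150 nM, within 50 nM to 450 nM, an expected step of a 1.2-fold higher number from compound 2 to compound 4 (0.07 log units; within the scatter).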

Compound 4, half-maximal effective concentration: 292 nM
For compound 4 the middle estimate is 1.9-fold (0.29 log units) below the measured one; measured number inside the range.
By their numbers in this assay, from the lowest: compound 2; then compound 4; then compounds 1 and 3 (each within the scatter of the next).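

The change from 2-methylbenzyl to 2-chlorobenzyl gives a 2.3-fold higher number from compound 2 to compound 4 (0.36 log units; beyond the scatter) in this assay, the first sign among these compounds that this aromatic carbon, ortho to a large group, is sensitive to which small group it carries. The step is modest, so chloro is accepted here, although methyl gives the lower number. Nothing available explains the difference between the two groups. Going by these compounds, whether fluoro, methoxy or plain benzyl would give a number lower than that of compound 2 remains open. Also open, on these data alone, is whether chloro would give a similar step on other carbons of this ring.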